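A few compounds are considered here, and "the series" means these few. Any claim that something is new, unique, unknown or untested is made for them only; others in the source may bear on it.

The measured compounds, all tested in a functional assay on HCT-116 cells (Homo sapiens) for cytotoxicity, read by resazurin assay, with a stated time of 48 h (a higher number here means that more compound is needed for the effect, a lower number that less compound is needed), are these:

Compound 1, `O=C(/C=C/c1ccccc1)c1ccc(NC(=O)c2cccs2)cc1`, gives 12000 nM.
Compound 2, `O=C(/C=C/c1ccccc1)c1ccc(NC(=O)c2ccccc2)cc1`, gives 17000 nM.
Compound 3, `O=C(/C=C/c1cccc([N+](=O)[O-])c1)c1ccc(NC(=O)c2cccs2)cc1`, gives 2600 nM.

Compound 4, `O=C(/C=C/c1cccc([N+](=O)[O-])c1)c1ccc(NC(=O)c2ccccc2)cc1`, has not yet been measured. It differs from compound 3 in one place: phenyl in place of thiophen-2-yl on a carbonyl carbon. The same structural change has already been made once among the measured compounds, from compound 1 to compound 2, where it gave a 1.4-fold higher number from compound 1 to compound 2 (0.15 log units; within the scatter). In both pairs the place of the change is the same, a carbonyl carbon whose other neighbour is an amide-type nitrogen, so this is the same change set on a different core.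

The two cores differ as follows: nitro in place of hydrogen on an aromatic carbon. That difference, from compound 1 to compound 3, gave a 4.6-fold lower number from compound 1 to compound 3 (0.66 log units; beyond the scatter), which leaves compound 3 with the lowest number of the three.

What is expected for compound 4 rests on the earlier instance of the change. Since the step from compound 1 to compound 2 stayed within the scatter, the step from compound 3 to compound 4 is expected to be of the same kind, estimated as a 1.3-fold higher number from compound 3 to compound 4 (0.13 log units; within the scatter). Compound 4 is therefore estimated at 3500 nM in this assay. The expected range for compound 4 runs from 1800 nM to 7000 nM, taking in the usual scatter around a single repeated instance of this change.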

Compound 4, half-maximal effective concentration: 4100 nM
For compound 4 the middle estimate is 1.2-fold (0.07 log units) below the measured one, within the range that was stated.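

In this assay, the step of a 1.6-fold higher number from compound 3 to compound 4 (0.20 log units; within the scatter) agrees with the earlier instance of the same change, so phenyl in place of thiophen-2-yl on the carbonyl carbon carries from the core of compound 1 to the core of compound 3 with no visible difference: the same change on two cores in this assay, a 1.4-fold higher number (0.15 log units; within the scatter) from compound 1 to compound 2 and a 1.6-fold higher number (0.20 log units; within the scatter) from compound 3 to compound 4, 1.1-fold (0.05 log units) apart, within the scatter of two such steps

Read the other way round, the square of four compounds also tests the nitro group, and a 4.1-fold lower number from compound 2 to compound 4 (0.62 log units; beyond the scatter) shows that nitro in place of hydrogen on an aromatic carbon carries over between the two amides as well: the same change on two cores in this assay, a 4.6-fold lower number (0.66 log units; beyond the scatter) from compound 1 to compound 3 and a 4.1-fold lower number (0.62 log units; beyond the scatter) from compound 2 to compound 4, 1.1-fold (0.05 log units) apart, within the scatter of two such steps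

Going by these compounds alone, this shows that, in these four compounds, the two changes add up without one altering the size of the other, but it rests on only two instances of each change, and it neither explains the effect of the nitro group nor gives any ground for ranking phenyl against thiophen-2-yl.

Going by these compounds, how an amine or a carboxylic acid in place of the nitro group would behave, or a longer chain in place of phenyl or thiophen-2-yl on the carbonyl carbon, stays open. Also open, on these data alone, is whether the same agreement between cores would hold outside this assay.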